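Replacing Ethyl with Ethynyl on the Aromatic Ring

This account rests on a few compounds, and the source may have more. Where it says the series, first, only, none or still open, it means among the compounds named here.

Measured in a functional assay on L1210 cells (Mus musculus) for inhibition; a lower number here means a stronger inhibitor, a higher number a weaker inhibitor:
Compound 1 `C#CCN(Cc1ccc2nc(C)nc(O)c2c1)c1cccc(CC)c1`: 5000 nM
Compound 2 `C#CCN(Cc1ccc2nc(C)nc(O)c2c1)c1cccc(Br)c1`: 1800 nM

Of the two measured compounds, compound 1 has the higher number, at 5000 nM. The unmeasured compound 3 `C#CCN(Cc1ccc2nc(C)nc(O)c2c1)c1cccc(C#C)c1` differs from it by ethynyl in place of ethyl on an aromatic carbon. Among the compounds with values here, one measured step bears on this change, also starting from the ethyl group: a 2.8-fold lower number from compound 1 to compound 2 (0.44 log units; beyond the scatter). Within the data shown here, that step is modest, and no measured compound carries ethynyl, so a similar or smaller drop is expected in this assay. The estimated step is a 2.0-fold lower number from compound 1 to compound 3 (0.30 log units; within the scatter). Compound 3 is expected at 2500 nM, within an estimated range of 1000 nM to 6000 nM.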

Compound 3, half-maximal inhibitory concentration: > 2400 nM
Compound 3 was reported as a limit; the forecaster's own chance of this, stated with the estimate: 3%; the middle value does not contradict the limit.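

Ethynyl at this position gives a limit rather than a number in this assay, and that limit belongs to compound 3: the limit of > 2400 nM in this assay, at which 1 of the 3 values shown sits. The change from bromo to ethynyl reads as an at least 1.3-fold higher number from compound 2 to compound 3 (0.12 log units; that floor lies within the scatter) and so separates the two groups only weakly. The step from ethyl to ethynyl cannot be read, leaving ethynyl unplaced relative to ethyl.

As far as these compounds go, the true value of compound 3 remains open. So does whether an amine, a carboxylic acid or a longer chain at this position would give a lower number than bromo.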